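Fluoro for Methyl: Predicting Compound 4

The source may report more compounds than this note shows. Statements on the series, on what has been measured and on what is new or still open speak of the compounds shown alone.

Of the compounds shown here, three have so far been measured in an in vitro assay on BTI-TN-5B1-4 cells for inhibition of Amine oxidase [flavin-containing] B (Homo sapiens); on this read-out lower numbers stand for stronger inhibition and higher numbers for weaker inhibition. Compound 1 `COc1ccc2c(c1)OC(c1ccccc1)CC2=O` gives 1470 nM. Compound 2 `Cc1ccc(-c2cc(=S)c3ccc(F)cc3o2)cc1` gives 1610 nM, and compound 3 `COc1ccc(-c2cc(=S)c3ccccc3o2)cc1` gives 480 nM. Compound 2 thus carries the highest number of the three; its gap to compound 1 lies within the scatter, whereas compound 3 stands beyond the scatter with the lower number. Compound 4 `Fc1ccc(-c2cc(=S)c3ccc(F)cc3o2)cc1` has not yet been measured. It differs from compound 2 by fluoro in place of methyl on an aromatic carbon, on an aromatic carbon of a six-membered aromatic ring of carbon only, para to a large group. Among the measured compounds shown here, no measured pair shows this exact change, so the step size rests on expectation alone. The account expects a 1.3-fold lower number from compound 2 to compound 4 (0.13 log units; within the scatter) to remain within the scatter in this assay, leaning if anything toward a lower number. Compound 4 is accordingly estimated at 1200 nM, within a range from 400 nM to 3600 nM.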

Compound 4, half-maximal inhibitory concentration: 6890 nM
Compound 4: middle estimate off by 5.7-fold (0.76 log units), on the low side; measured number outside the range, above it.
By their numbers in this assay, from the lowest: compound 3; then compounds 1 and 2 (each within the scatter of the next); then compound 4.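

In this assay fluoro in place of methyl on an aromatic carbon, para to a large group, brings a 4.3-fold higher number from compound 2 to compound 4 (0.63 log units; beyond the scatter) and so places compound 4 on the weak side of the series. Among the compounds shown here, this is the first sign that the read-out responds to the group held at this position, which the earlier compounds could not show. Nothing measured here accounts for the step. Still open, as far as these compounds go, is whether chloro, trifluoromethyl or an amine at this position would stay near compound 2 or move as fluoro does.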